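Vero cell cytotoxicity: from compound 1 to compound 4

The source may hold more compounds than are shown below. What is called first, only, known or untested is meant among the compounds shown, and "the series" means these compounds.

In an ADME assay on Vero cells (Chlorocebus sabaeus) for cytotoxicity, read by resazurin assay, with a stated time of 3 days (on this read-out lower numbers stand for stronger inhibition and higher numbers for weaker inhibition), compound 1 `CCCCCC(=O)Nc1cc2nc(C3CCCCC3)[nH]c2cc1N1CCCC1` reaches only the limit > 100 ug/mL.
Compound 2 `CCCCOC(=O)Nc1cc2nc(C3CCCCC3)[nH]c2cc1N(C)C` likewise gives the limit > 100 ug/mL in this assay.
Compound 3 `CCCCCC(=O)Nc1cc2nc(C3CCCCC3)[nH]c2cc1N(C)C` too sits at the limit > 100 ug/mL in this assay.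

Compound 1 thus stands at a limit rather than a number, and the limit of > 100 ug/mL in this assay, at which 3 of the 3 values shown sit, holds for every value measured here. The two single-place steps that touch it, a step that the two limits leave unreadable from compound 1 to compound 3 and a step that the two limits leave unreadable from compound 2 to compound 3, are both unreadable. Compound 4 `O=C(Nc1cc2nc(C3CCCCC3)[nH]c2cc1N1CCCC1)OCC(F)(F)F` differs from compound 1 by 2,2,2-trifluoroethoxy in place of pentyl on a carbonyl carbon. The closest comparison is a step that the two limits leave unreadable from compound 2 to compound 3, in which butoxy stood on the carbonyl carbon before the change, and it also lies between two limits. No step beyond the scatter is therefore expected in this assay. Compound 4 is estimated at 150 ug/mL, within 60 ug/mL to 400 ug/mL. This means an expected step that the limit leaves unreadable from compound 1 to compound 4.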

Compound 4, half-maximal inhibitory concentration: > 100 ug/mL
Compound 4: a limit, no number; the forecaster's own chance of this, stated with the estimate: 85%; the middle value is on the limit's open side.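

In this assay compound 4 gives > 100 ug/mL, a limit and not a number, so no step can be read from compound 1 to compound 4. The compounds shown leave open whether they differ at all in this assay: the limit of > 100 ug/mL in this assay, at which 4 of the 4 values shown sit.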